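Halogen swap on the sulfonyl aryl within the two cores

The source may hold more compounds than are shown below. What is called first, only, known or untested is meant among the compounds shown, and "the series" means these compounds.

Measured compounds:
compound 1 `O=C(/C=C/c1ccc2c(c1)OCCO2)NS(=O)(=O)c1ccc(Cl)cc1` in a functional assay on MCF7 cells (Homo sapiens) for antiproliferative activity, read by MTT assay, with a stated time of 48 h (on this read-out higher numbers stand for weaker inhibition and lower numbers for stronger inhibition), gives 51.3 ug/mL.
compound 2 `O=C(/C=C/c1ccc2c(c1)OCCO2)NS(=O)(=O)c1ccc(Br)cc1` gives only a limit of the assay, > 100 ug/mL.
compound 3 `O=C(/C=C/c1ccc2c(c1)OCCCO2)NS(=O)(=O)c1ccc(Cl)cc1` gives only a limit of the assay, > 100 ug/mL.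

Within the data shown here, the single counted change among the measured compounds is bromo in place of chloro on an aromatic carbon, and it made a step of an at least 1.9-fold higher number from compound 1 to compound 2 (0.28 log units; that floor lies within the scatter). How the core of compound 1 and the core of compound 3 differ is not broken down here.

Compound 4 `O=C(/C=C/c1ccc2c(c1)OCCCO2)NS(=O)(=O)c1ccc(Br)cc1` is not yet measured. It differs from compound 3 by bromo in place of chloro on an aromatic carbon; the place reads word for word as for the earlier change, so it is the same change. Compound 3 already sits at the limit of > 100 ug/mL in this assay, at which 2 of the 3 values shown sit, and the earlier change moved the number upward, so compound 4 is expected to stay at or beyond that limit, an expected step that the limit leaves unreadable from compound 3 to compound 4. The estimate for compound 4 is 150 ug/mL, from 80 ug/mL to 400 ug/mL.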

Compound 4, half-maximal inhibitory concentration: > 100 ug/mL
Compound 4: only a limit was reported (the forecaster's own chance of this, stated with the estimate: 80%); the middle value lies beyond the limit too.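

Compound 3 and compound 4 each give only a limit, so no step can be read for bromo in place of chloro on this core: the limit of > 100 ug/mL in this assay, at which 3 of the 4 values shown sit.

The compounds shown leave open how far compound 3 and compound 4 actually lie beyond that limit.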